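Aryl change on the shared core of compound 2

A few compounds are considered here, and "the series" means these few. Any claim that something is new, unique, unknown or untested is made for them only; others in the source may bear on it.

Compound 2 `O=C(O)Cc1sc(C(c2ccc(F)cc2)c2ccc(F)cc2)nc1-c1ccco1` is measured in an in vitro functional assay on HEK285-7 cells for antagonist activity at prostaglandin D2 receptor 2 (Homo sapiens), read by BRET and beta-arrestin recruitment (on this read-out lower numbers stand for smaller maximal responses and higher numbers for larger maximal responses), and gives 80%. Compound 3 `COc1ccc(OC)c(-c2nc(C(c3ccccc3)c3ccccc3)sc2CC(=O)O)c1` gives 80% in this assay, level with compound 2 at the digits shown and within the scatter; together these two are the highest of the three numbers. Compound 1 `O=C(O)Cc1sc(Cc2ccccc2)nc1-c1ccc(Cl)cc1` gives 50% in this assay, a number lower than that of compound 2 by a margin beyond the scatter. Going by the values given here, no two of these three compounds differ in one place only, so no single measured step is at hand.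

Compound 4 `Cc1cc(-c2nc(C(c3ccc(F)cc3)c3ccc(F)cc3)sc2CC(=O)O)ccn1` is the next compound. It differs from compound 2 as follows: 2-methylpyridin-4-yl in place of furan-2-yl on an aromatic carbon. The group that enters is 2-methylpyridin-4-yl, the group that leaves is furan-2-yl, and the place is an aromatic carbon of the five-membered aromatic ring with 1 nitrogen and 1 sulfur.

Compound 3 carries a different group at this place and still gives 80% in this assay, so the step is expected to stay within the scatter, with a number 5 percentage points lower from compound 2 to compound 4 (within the scatter) as the estimated step; compound 1 differs in more than one place and is not a test of this. Compound 4 is expected to give 75% in this assay, with a range from 50% to 90%.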

Compound 4, largest response reached (reported as efficacy), in percent of the reference or control that the assay uses: 80%
The estimate for compound 4 lay 5 percentage points below the measured number, within the range that was stated.
By their numbers in this assay, from the lowest: compound 1; then compounds 2, 3 and 4 (each within the scatter of the next).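

In this assay, 2-methylpyridin-4-yl in place of furan-2-yl on this aromatic carbon gives no change at the digits printed from compound 2 to compound 4 (within the scatter), the only single-place step shown at this position. With the rest of compound 2 unchanged, the maximal response therefore holds when a five-membered aromatic ring with 5 heavy atoms gives way to a six-membered aromatic ring with 7 heavy atoms, each with 1 hetero atom and 1 hydrogen-bond acceptor. No available evidence bears on this result.

Open, going by these compounds, is whether a saturated amine such as piperidin-4-yl or a small alkyl group such as methyl would hold the response at this place, since only aromatic rings appear here. Also open, on these data alone, is what the methyl of 2-methylpyridin-4-yl contributes, as a comparison with pyridin-4-yl would be needed to separate it from the ring change.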